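Methyl in place of hydrogen on an aromatic oxygen

This account rests on a few compounds, and the source may have more. Where it says the series, first, only, none or still open, it means among the compounds named here.

Compound 1 `O=C(Nc1cccc(-n2cc(-c3ccncc3)c(-c3cc(O)cc(Cl)c3)n2)c1)Nc1ccc(Cl)c(Cl)c1`: 99%
Compound 2 `COc1cc(Cl)cc(-c2nn(-c3cccc(NC(=O)Nc4cc(C(F)(F)F)cc(C(F)(F)F)c4)c3)cc2-c2ccncc2)c1`: 95%

In a functional assay on A549 cells (Homo sapiens) for inhibition, read by sulforhodamine B assay, with a stated time of 48 h, tested at 0.1 uM (a lower number here means a stronger effect, a higher number a weaker effect of the compound at the concentration tested), compound 1 gives 99%, the higher of the two numbers, while compound 2 gives 95%, a gap that lies within the usual scatter. Compound 3 `COc1cc(Cl)cc(-c2nn(-c3cccc(NC(=O)Nc4ccc(Cl)c(Cl)c4)c3)cc2-c2ccncc2)c1` has not been measured. It differs from compound 1 by methyl in place of hydrogen on an oxygen on an aromatic ring. Among the measured compounds shown here, no measured pair shows this change on its own, so the step is expected to be small in either direction, staying within the scatter, because compound 2 already carries the methoxy group and gives 95%. Compound 3 is therefore expected at 96%, within 85% to 102%, an estimated step of a number 3 percentage points lower from compound 1 to compound 3 (within the scatter).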

Compound 3, a percentage reported as activity, at one concentration (the size of the read-out at that concentration, not a potency): 97%
For compound 3 the middle estimate is 1 percentage points below the measured one, within the range that was stated.
By their numbers in this assay, from the lowest: compounds 2, 3 and 1 (each within the scatter of the next).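

In this assay, among the compounds shown here, the swap of hydroxy to methoxy on the 3-chloro-5-hydroxyphenyl group gives a number 2 percentage points lower from compound 1 to compound 3 (within the scatter), the first view of this change on its own. At this concentration, the read-out therefore does not tell the two groups apart at this position. Nothing at hand bears on why this is so. The compounds shown leave open how an ethoxy group, or an amine in place of the oxygen, would read. They also leave open whether hydroxy and methoxy would stay indistinguishable at other concentrations.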